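The source may report more compounds than this note shows. Statements on the series, on what has been measured and on what is new or still open speak of the compounds shown alone.

Of the compounds shown here, two have been measured so far in a physicochemical assay for lipophilicity, measured as octanol-water partition, at pH 7.4; on this read-out lower numbers stand for lower lipophilicity and higher numbers for higher lipophilicity. Within the data shown here, compound 1 `Cc1ccc2[nH]c(C(=O)N[C@H]3CCN(S(=O)(=O)c4ccccc4)C[C@@H]3C(=O)NCCN(C)C)cc2c1` gives 2.2, and compound 2 `Cc1ccc2[nH]c(C(=O)N[C@@H]3CCN(S(=O)(=O)c4ccccc4)C[C@H]3C(=O)NCCN(C)C)cc2c1` gives 2.3, so compound 2 stands level with its only measured neighbour. Compound 3 `Cc1ccc2[nH]c(C(=O)N[C@@H]3CCN(S(=O)(=O)c4ccccc4)C[C@@H]3C(=O)NCCN(C)C)cc2c1` now raises a question of shape alone: the two compounds have the same atoms and bonds and differ only in configuration as drawn: 1 of 2 stereo elements differ; a stereocentre at a saturated ring carbon is drawn R in compound 2 and S in compound 3. Among the measured compounds shown here, only one measured step bears on this change: a number 0.10 log units higher from compound 1 to compound 2 (within the scatter), which comes with the fact that compounds 1 and 2 differ only in the configuration as drawn. That step inverted both stereocentres and gave mirror images, whereas the new change inverts only one, so it is a loose guide. A shift beyond the scatter is therefore not expected, and no direction can be favoured. The expected change is no change at the digits printed from compound 2 to compound 3 (within the scatter). For compound 3 the estimate is 2.3, with an expected range from 1.9 to 2.7.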

Compound 3, distribution coefficient: 2.1
For compound 3 the middle estimate is 0.20 log units above the measured one, and the stated range covers the measured number.
By their numbers in this assay, from the lowest: compounds 3, 1 and 2 (each within the scatter of the next).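

In this assay, inverting one stereocentre rather than both also leaves the number within the scatter: the result is a number 0.20 log units lower from compound 2 to compound 3 (within the scatter), and the other single inversion gives a number 0.10 log units lower from compound 1 to compound 3 (within the scatter). The earlier compounds shown here showed this only for a mirror-image pair, whereas all three compounds now sit within the scatter of one another, so at these two ring positions neither a single nor a double inversion separates them on this read-out. These comparisons test shape alone, since nothing else changes: the fact that compounds 2 and 3 differ only in the configuration as drawn.

The mirror image of compound 3 remains an open case, as does whether configuration matters on any other read-out. Also open, as far as these compounds go, is how far the number would move with a carboxylic acid or a longer chain on the shared core.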